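Ring changes on the pendant bicycle and hepatocyte clearance

This account rests on a few compounds, and the source may have more. Where it says the series, first, only, none or still open, it means among the compounds named here.

Measured so far in an ADME assay on cells (Hepatocyte, Rattus norvegicus) for metabolic stability, using equilibrium dialysis; a lower number here means slower removal, a higher number faster removal of the compound:
compound 1 `CC(=O)N[C@@H]1CCC[C@H](C(=O)Nc2cc(-c3cnc4n3CCCC4)c(Cl)cn2)C1` gives 12 uL/min
compound 2 `CC(=O)N[C@@H]1CCC[C@H](C(=O)Nc2cc(-c3cnc4n3CCC4)c(Cl)cn2)C1` gives 19 uL/min
compound 3 `CC(=O)N[C@@H]1CCC[C@H](C(=O)Nc2cc(-c3cnn4c3CCCCC4)c(Cl)cn2)C1` gives 51 uL/min

Compound 3 stands highest of the three in this assay. Its nearest neighbour is compound 2, with a 2.7-fold higher number from compound 2 to compound 3 (0.43 log units; beyond the scatter); furthest is compound 1, with a 4.3-fold higher number from compound 1 to compound 3 (0.63 log units; beyond the scatter). Between the two smaller bicycles the difference is a 1.6-fold higher number from compound 1 to compound 2 (0.20 log units; within the scatter), so only the step up to the seven-membered non-aromatic ring of compound 3 stands out.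

Compound 4 `CC(=O)N[C@@H]1CCC[C@H](C(=O)Nc2cc(-c3cnn4c3NCCC4)c(Cl)cn2)C1` differs from compound 3 in one place: a group of 9 heavy atoms (6 carbon, 3 nitrogen; one five-membered aromatic ring with 2 hetero atoms, one six-membered non-aromatic ring with 2 hetero atoms) in place of a group of 10 heavy atoms (8 carbon, 2 nitrogen; one five-membered aromatic ring with 2 hetero atoms, one seven-membered non-aromatic ring with 1 hetero atom), on an aromatic carbon. The measured steps bear on the ring-size part of this change, since both routes to compound 3 raised the number beyond the scatter, while the added ring nitrogen and its hydrogen-bond donor are not probed by any measured pair. A modest drop back toward the numbers of compound 1 and compound 2 is therefore expected, roughly a 2.6-fold lower number from compound 3 to compound 4 (0.41 log units; beyond the scatter), with wide uncertainty. For compound 4 the estimate in this assay is 20 uL/min, expected between 8 uL/min and 50 uL/min.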

Compound 4, intrinsic clearance in a liver preparation (reported as CLH), per the amount of preparation that the assay uses: 10 uL/min
Beside the measured number, compound 4's estimate is 2.0-fold (0.30 log units) above it; measured number inside the range.
By their numbers in this assay, from the lowest: compounds 4, 1 and 2 (each within the scatter of the next); then compound 3.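

In this assay, the step away from the seven-membered non-aromatic ring is beyond the scatter (a 5.1-fold lower number from compound 3 to compound 4 (0.71 log units; beyond the scatter)), while the six-membered non-aromatic ring with 2 hetero atoms cannot be told apart from the two smaller bicycles (a 1.9-fold lower number from compound 2 to compound 4 (0.28 log units; within the scatter); a 1.2-fold lower number from compound 1 to compound 4 (0.08 log units; within the scatter)). Among the four compounds, only compound 3 therefore stands apart, and a second ring nitrogen with its hydrogen-bond donor on the six-membered ring does not separate compound 4 from compound 1. Nothing measured here accounts for these numbers.

Ring size and the ring nitrogen change together from compound 3 to compound 4, so their separate shares stay unresolved. Also open, going by these compounds, is how a ring oxygen, or a methyl group on the ring nitrogen, would read against compound 4.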